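A few compounds are considered here, and "the series" means these few. Any claim that something is new, unique, unknown or untested is made for them only; others in the source may bear on it.

Measured compounds:
compound 1, `CCCCC[C@H](C(C)C)C(c1ccc(O)c(OC)c1)c1ccc(O)c(OC)c1`, 9200 nM
compound 2, `COc1ccc(C(c2ccc(OC)c(OC)c2)[C@H](C)[C@@H](C)CO)cc1OC`, 67000 nM

In a functional assay on HeLa cells (Homo sapiens) for cytotoxicity, read by WST assay, with a stated time of 48 h (on this read-out lower numbers stand for stronger inhibition and higher numbers for weaker inhibition), compound 1 gives 9200 nM. Compound 2 gives 67000 nM in this assay, the higher of the two numbers and the weaker result; the gap to compound 1 lies beyond the usual scatter, so on the evidence shown compound 2 is the weaker of the two.

The account now follows compound 2 to compound 3, `COc1ccc(C(c2ccc(OC)c(OC)c2)[C@@H](C)[C@@H](C)CO)cc1OC`. The change is the two compounds have the same atoms and bonds and differ only in configuration as drawn: 1 of 2 stereo elements differ; a stereocentre at a saturated chain carbon is drawn S in compound 2 and R in compound 3. Nothing leaves and nothing enters; only the configuration drawn at one saturated chain carbon is turned from S to R.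

Among the measured compounds shown here, no comparable step between measured compounds is known here, so the size of the effect cannot be read from the data. A change confined to one stereocentre in a flexible chain is expected to move this assay only modestly, and the estimated step from compound 2 to compound 3 is a 1.3-fold lower number from compound 2 to compound 3 (0.13 log units; within the scatter). Compound 3 is therefore estimated at 50000 nM in this assay, within a range of 15000 nM to 200000 nM.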

Compound 3, half-maximal inhibitory concentration: > 100000 nM
Compound 3 ended at the assay's limit; the forecaster's own chance of this, stated with the estimate: 20%; middle value at least 2.0-fold (0.30 log units) away from the limit.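

In this assay compound 3 gives > 100000 nM, which is a limit of the assay and not a number. Turning this saturated chain carbon from S to R gives an at least 1.4-fold higher number from compound 2 to compound 3 (0.17 log units; that floor lies within the scatter), so the first look at this stereocentre yields only a floor, and that floor alone does not establish a real loss on inversion. Any difference between this pair can come only from the configuration at this one carbon, since nothing else separates them: the fact that compounds 2 and 3 differ only in the configuration as drawn

The compounds shown leave open how far the true value of compound 3 lies past the limit and what a change at the other stereocentre would do. They also leave open how a carboxylic acid or an amine on the chain would read in this assay.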